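A few compounds are considered here, and "the series" means these few. Any claim that something is new, unique, unknown or untested is made for them only; others in the source may bear on it.

Three compounds share one core and differ only in the side chain attached to the nitrogen on the aromatic ring. Compound 1 `O=S(=O)(NCCCNc1nccc(-c2c(-c3cccc(F)c3)nc3sccn23)n1)c1ccc(C(F)(F)F)cc1` carries a ((4-(trifluoromethyl)phenyl)sulfonyl)amino group on the longer chain; in a functional assay on A-375 cells (Homo sapiens) for cytotoxicity, read by MTT assay (a higher number here means a weaker inhibitor, a lower number a stronger inhibitor), compound 1 gives 4090 nM. Compound 2 `O=C(NCCCNc1nccc(-c2c(-c3cccc(F)c3)nc3sccn23)n1)c1ccc(Cl)cc1` carries a ((4-chlorophenyl)carbonyl)amino group on that chain, and in this assay compound 2 gives 13700 nM. Compound 3 `O=S(=O)(NCCNc1nccc(-c2c(-c3cccc(F)c3)nc3sccn23)n1)c1ccc(Cl)cc1` carries a ((4-chlorophenyl)sulfonyl)amino group on the shorter chain, and in this assay compound 3 gives 18600 nM. Among these three numbers compound 2 stands second highest; its nearest neighbour is compound 3, reached by the step of a 1.4-fold higher number from compound 2 to compound 3 (0.13 log units; within the scatter), while compound 1 lies furthest from it, with a lower number that falls beyond the scatter.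

Compound 4 `O=S(=O)(NCCNc1nccc(-c2c(-c3cccc(F)c3)nc3sccn23)n1)c1ccc(Br)cc1` has not yet been measured. Compared with compound 2 it shows this change: ((4-bromophenyl)sulfonyl)amino in place of (((4-chlorophenyl)carbonyl)amino)methyl on a saturated chain carbon, two bonds along the chain from a nitrogen on an aromatic ring. Within the data shown here, one measured step bears on it: a 1.4-fold higher number from compound 2 to compound 3 (0.13 log units; within the scatter), which made the same exchange of the carbonyl-linked group for a sulfonyl-linked one on the shorter chain while keeping chlorine, and was small. Among the measured compounds shown here, no measured pair compares bromine with chlorine on this ring. The expected step from compound 2 to compound 4 is therefore a 1.2-fold higher number from compound 2 to compound 4 (0.07 log units; within the scatter), which is none beyond the scatter. For compound 4 in this assay the estimate is 16000 nM, with a range from 5500 nM to 45000 nM.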

Compound 4, half-maximal inhibitory concentration: 13500 nM
Beside the measured number, compound 4's estimate is 1.2-fold (0.07 log units) above it, and the stated range covers the measured number.
By their numbers in this assay, from the lowest: compound 1; then compounds 4, 2 and 3 (each within the scatter of the next).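

In this assay, among these compounds, the exchange of bromo for chloro on an aromatic carbon gives a 1.4-fold lower number from compound 3 to compound 4 (0.14 log units; within the scatter) and so provides the first direct reading at this halogen position, one that stays within the scatter. The whole exchange on the saturated chain carbon, ((4-bromophenyl)sulfonyl)amino in place of (((4-chlorophenyl)carbonyl)amino)methyl, gives a 1.0-fold lower number from compound 2 to compound 4 (0.01 log units; within the scatter) and also stays within the scatter, as the same exchange with chloro did in a 1.4-fold higher number from compound 2 to compound 3 (0.13 log units; within the scatter) for these compounds. Among compounds 2, 3 and 4, neither the halogen nor this combined exchange of linking group and chain therefore moves the number beyond the scatter.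

As far as these compounds go, compound 1 differs from compound 4 in both its chain and its ring substituent, so its number cannot be assigned to either change, and it remains open how a methoxy group or an amine on that ring, or a longer chain with the same sulfonyl group, would read. No supporting measurement accounts for how small these steps are.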